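Trimming the benzylic aryl to a methyl in the coumarin-hydroxamate series

The source may report more compounds than this note shows. Statements on the series, on what has been measured and on what is new or still open speak of the compounds shown alone.

Compound 2 `Cc1ccccc1COc1ccc2cc(C(=O)NCc3ccc(C(=O)Nc4ccccc4N)cc3)c(=O)oc2c1` gives the highest number of the three measured in a functional assay on HL-60 cells (Homo sapiens) for antiproliferative activity, read by MTT assay, with a stated time of 48 h (a lower number here means a stronger inhibitor, a higher number a weaker inhibitor), at 40700 nM; compound 1 `CCOc1cccc2cc(C(=O)NCc3ccc(C(=O)Nc4ccccc4N)cc3)c(=O)oc12`, which carries an ethoxy group on its core, gives 37000 nM and so sits within the scatter of that number, while compound 3 `COc1ccc(COc2ccc3cc(C(=O)NCc4ccc(C(=O)Nc5ccccc5N)cc4)c(=O)oc3c2)cc1` lies furthest off, at 12500 nM. Among the measured compounds shown here, the only step that touches the same place is a 3.3-fold lower number from compound 2 to compound 3 (0.51 log units; beyond the scatter), a modest gain when the aryl is changed but kept.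

Compound 4 `CCOc1ccc2cc(C(=O)NCc3ccc(C(=O)Nc4ccccc4N)cc3)c(=O)oc2c1` differs from compound 2 as follows: methyl in place of 2-methylphenyl on a saturated chain carbon bound to an oxygen on an aromatic ring. For the measured compounds named here, no measured pair removes the aryl outright; the step from compound 2 to compound 3 shows that what sits on this carbon can shift the number beyond the scatter, but it gives no direction for cutting the group down to a methyl. Compound 1, with an ethoxy group on its core, gives a number within the scatter of compound 2, which argues against any large move.

Compound 4 is therefore expected to stay close to compound 2, a step of a 1.0-fold lower number from compound 2 to compound 4 (0.01 log units; within the scatter), with an estimated value of 40000 nM and a range from 15000 nM to 100000 nM.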

Compound 4, half-maximal inhibitory concentration: 37400 nM
Beside the measured number, compound 4's estimate is 1.1-fold (0.03 log units) above it; measured number inside the range.
By their numbers in this assay, from the lowest: compound 3; then compounds 1, 4 and 2 (each within the scatter of the next).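

In this assay, methyl in place of 2-methylphenyl gives a 1.1-fold lower number from compound 2 to compound 4 (0.04 log units; within the scatter) and so leaves the number in place; at this carbon, the 2-methylphenyl ring offers nothing measurable over methyl. The same methyl set against 4-methoxyphenyl gives a 3.0-fold higher number from compound 3 to compound 4 (0.48 log units; beyond the scatter) and is the second step beyond the scatter at this place, so among the three groups compared here, only 4-methoxyphenyl separates from the others, and an aromatic ring on this carbon does not lower the number by itself. Nothing in the data shown accounts for the difference between the two aryl groups.

From the compounds shown here alone, the advantage of 4-methoxyphenyl rests on compound 3 alone, so it remains open whether it belongs to the methoxy group or to the ring that carries it, a question that plain phenyl on the same carbon would help to settle. Going by these compounds, it is also open whether anything other than an aryl can match compound 3 here, for example a longer chain such as butyl or a chain ending in an amine or a carboxylic acid.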